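Fluorine for methyl on the amide aryl ring

This account rests on a few compounds, and the source may have more. Where it says the series, first, only, none or still open, it means among the compounds named here.

Compound 1, `COc1ccc(NC(=O)CN2CCN(S(=O)(=O)N3CCC(C)CC3)CC2)cc1`, gives in an assay on HEK293 cells for activation of potassium channel subfamily T member 1 (Homo sapiens), read by thallium flux (a higher number here means that more compound is needed for the effect, a lower number that less compound is needed), a value of > 10000 nM, which is a limit of the assay rather than a number.
Compound 2, `COc1ccc(Cl)cc1NC(=O)CC1CCN(S(=O)(=O)N2CCC(C)CC2)CC1`, gives in this assay 9300 nM.
Compound 3, `Cc1ccc(NC(=O)CN2CCN(S(=O)(=O)N3CCC(C)CC3)CC2)cc1`, gives in this assay 4100 nM.

Among the numbers shown, compound 3 has the lowest; compound 2 sits an at least 2.4-fold lower number from compound 1 to compound 3 (0.38 log units; beyond the scatter) is not relevant here, but the gap from compound 3 to compound 2 is beyond the scatter, and compound 1 sits at the limit (the limit of > 10000 nM in this assay, at which 1 of the 3 values shown sits). Within the data shown here, the only measured step, an at least 2.4-fold lower number from compound 1 to compound 3 (0.38 log units; beyond the scatter), shows that exchanging one small group on the aromatic ring can move the number beyond the scatter.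

Compound 4, `CC1CCN(S(=O)(=O)N2CCN(CC(=O)Nc3ccccc3F)CC2)CC1`, differs from compound 3 by 2-fluorophenyl in place of 4-methylphenyl on an amide-type nitrogen. Among the measured compounds shown here, no measured step involves a fluorine, so the step of an at least 2.4-fold lower number from compound 1 to compound 3 (0.38 log units; beyond the scatter) is only a loose guide: it shows the ring substituent matters, not which way a fluorine will pull. The expected step is a 1.6-fold higher number from compound 3 to compound 4 (0.20 log units; within the scatter), a modest rise that may lie within the scatter. Compound 4 is therefore estimated at 6500 nM in this assay, expected between 2000 nM and 20000 nM.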

Compound 4, half-maximal effective concentration: > 10000 nM
Compound 4: no number, only a limit (the forecaster's own chance of this, stated with the estimate: 35%); at least 1.5-fold (0.18 log units) between middle value and limit.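

In this assay, putting 2-fluorophenyl in place of 4-methylphenyl on the amide-type nitrogen gives an at least 2.4-fold higher number from compound 3 to compound 4 (0.38 log units; beyond the scatter). Among these compounds, the earlier compounds showed only that a change on this aryl ring could lower the number; this step shows that another change there can raise it, so the ring of compound 3 cannot be exchanged freely. Compound 4 gives a limit of the assay rather than a number, and the step between compound 1 and compound 4 cannot be read: the limit of > 10000 nM in this assay, at which 2 of the 4 values shown sit.

This change replaces the methyl group with fluorine and also alters where the ring carries its substituent, and the compounds shown do not separate these two differences. They also leave open how a nitrile or a trifluoromethyl group on this ring would read.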